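What a Ring Swap May Do to Compound 3

A few compounds are considered here, and "the series" means these few. Any claim that something is new, unique, unknown or untested is made for them only; others in the source may bear on it.

In an ADME assay on L02 cells (Homo sapiens) for cytotoxicity, read by MTT assay, with a stated time of 24 h (on this read-out lower numbers stand for stronger inhibition and higher numbers for weaker inhibition), compound 1 (`COc1cc(/C=C2\CN(S(=O)(=O)c3ccc(NC(C)=O)cc3)C/C(=C\c3ccccc3F)C2=O)cc(OC)c1OC`) gives 14000 nM and compound 2 (`COc1cc(/C=C2\CN(S(=O)(=O)c3ccc(NC(C)=O)cc3)C/C(=C\c3ccccc3F)C2=O)cc(OC)c1`) gives 15400 nM while compound 3 (`COc1cc(/C=C2\CN(S(=O)(=O)c3ccc(NC(C)=O)cc3)C/C(=C\c3ccc(C#N)cc3)C2=O)cc(OC)c1OC`) gives 13600 nM so all three sit within the scatter of one another. Compound 4 (`COc1cc(/C=C2\CN(S(=O)(=O)c3ccc(NC(C)=O)cc3)C/C(=C\c3cc(OC)c(OC)c(OC)c3)C2=O)cc(OC)c1`) differs from compound 3 by one swap: 3,5-dimethoxyphenyl in place of 4-cyanophenyl on a double-bonded chain carbon bound to a double-bonded ring carbon with 3,5-dimethoxyphenyl in place of 4-cyanophenyl on a double-bonded chain carbon bound to a double-bonded ring carbon. A ring change at this same place gave a 1.0-fold lower number from compound 1 to compound 3 (0.01 log units; within the scatter) and hydrogen in place of methoxy on an aromatic carbon gave a 1.1-fold higher number from compound 1 to compound 2 (0.04 log units; within the scatter) so neither moved the number beyond the scatter. The expected change is therefore a 1.0-fold higher number from compound 3 to compound 4 (0.01 log units; within the scatter) in this assay and nothing larger. Compound 4 is estimated at 14000 nM with an expected range from 8500 nM to 23000 nM on this read-out.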

Compound 4, half-maximal inhibitory concentration: 15900 nM
The estimate for compound 4 lay 1.1-fold (0.06 log units) below the measured number; the range from low to high includes it.
By their numbers in this assay, from the lowest: compounds 3, 1, 2 and 4 (each within the scatter of the next).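

At this place, on a double-bonded chain carbon bound to a double-bonded ring carbon, 3,5-dimethoxyphenyl joins 4-cyanophenyl and 2-fluorophenyl in giving numbers that cannot be told apart in this assay: the steps are a 1.2-fold higher number from compound 3 to compound 4 (0.07 log units; within the scatter), a 1.1-fold higher number from compound 1 to compound 4 (0.06 log units; within the scatter) and a 1.0-fold higher number from compound 2 to compound 4 (0.01 log units; within the scatter). So a ring carrying methoxy groups, with neither nitrile nor fluorine, fits the same flat picture, at least among these compounds. Nothing available explains this flatness. As far as these compounds go, whether an amine, a carboxylic acid or a longer chain at this place would give a number beyond the scatter remains open.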